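Bromo to methyl: a step expected within the scatter

This account rests on a few compounds, and the source may have more. Where it says the series, first, only, none or still open, it means among the compounds named here.

In a functional assay on B16-F10 cells (Mus musculus) for antiproliferative activity, read by colorimetric assay and MTT assay, with a stated time of 48 h (a lower number here means a stronger inhibitor, a higher number a weaker inhibitor), compound 1 (`Cc1ccc(S(=O)(=O)NC(=O)c2ccncc2)cc1`) gives 16200 nM and compound 2 (`O=C(NS(=O)(=O)c1ccc(F)cc1)c1ccccn1`) gives 10900 nM as its read-out. Compound 3 (`O=C(NS(=O)(=O)c1ccc(Br)cc1)c1ccccn1`) gives 8500 nM in the same test. Its value lies within the scatter of both others, so the three compounds do not separate on these numbers.

Compound 4 (`Cc1ccc(S(=O)(=O)NC(=O)c2ccccn2)cc1`) has methyl in place of bromo on an aromatic carbon, para to a large group (methyl in place of bromo on an aromatic carbon). Among the compounds with values here, the only measured step that bears on this change is a 1.3-fold lower number from compound 2 to compound 3 (0.11 log units; within the scatter) for bromo in place of fluoro on an aromatic carbon. Compound 1 also carries methyl, and its value of 16200 nM remains within the scatter of compound 3 as well. No step beyond the scatter is therefore expected in this assay for this exchange.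

The expected step is a 1.2-fold higher number from compound 3 to compound 4 (0.07 log units; within the scatter) and this estimate has no clear direction. For compound 4 the estimated value is 10000 nM with an expected range of 5500 nM to 18000 nM in this test.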

Compound 4, half-maximal inhibitory concentration: 16700 nM
Beside the measured number, compound 4's estimate is 1.7-fold (0.22 log units) below it, and the stated range covers the measured number.
By their numbers in this assay, from the lowest: compounds 3, 2, 1 and 4 (each within the scatter of the next).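

In this assay methyl on this aromatic carbon, para to a large group, gives a 2.0-fold higher number from compound 3 to compound 4 (0.29 log units; within the scatter) when it replaces bromo and a 1.5-fold higher number from compound 2 to compound 4 (0.19 log units; within the scatter) when it replaces fluoro, so methyl, fluoro and bromo at this place now all lie within the scatter of one another. Within the data shown here, compound 4 also gives the first comparison that isolates the group on the carbonyl carbon, since compound 1 differs from compound 2 and compound 3 in two places: pyridin-2-yl in place of pyridin-4-yl gives a 1.0-fold higher number from compound 1 to compound 4 (0.01 log units; within the scatter) with methyl held fixed. On these data alone, whether an amine or a carboxylic acid at this place on the ring, or pyridin-3-yl on the carbonyl carbon, would give a step beyond the scatter stays open. No measurement shown here accounts for the size of these steps.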